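A few compounds are considered here, and "the series" means these few. Any claim that something is new, unique, unknown or untested is made for them only; others in the source may bear on it.

Compound 1 `COC(=O)c1ccc(-c2cnc(CCCc3ccc(-c4ccccc4)cc3)o2)nc1`: 50000 nM
Compound 2 `O=C(O)c1ccc(-c2cnc(C(O)CCc3ccc(-c4ccccc4)cc3)o2)nc1`: 10000 nM

Both compounds were tested in an assay for inhibition of Fatty-acid amide hydrolase 1 (Rattus norvegicus); a lower number here means a stronger inhibitor, a higher number a weaker inhibitor. Of the two, compound 2 gives the lower number and compound 1 a higher one, a gap that lies beyond the usual scatter of repeated measurements, so compound 2 stands as the stronger inhibitor of the two. The next compound, compound 3 `COC(=O)c1ccc(-c2cnc(C(O)CCc3ccc(-c4ccccc4)cc3)o2)nc1`, differs from compound 2 in one place: methyl in place of hydrogen on an oxygen next to a carbonyl group. The rest of compound 2 is kept unchanged. Within the data shown here, no single-change step between measured compounds is available, so the size of this step is uncertain. A move toward a weaker inhibitor seems more likely than the reverse, because compound 1, which carries the same methoxycarbonyl group, gives 50000 nM. Compound 3 is therefore expected to show a step of a 2.5-fold higher number from compound 2 to compound 3 (0.40 log units; beyond the scatter). For compound 3 the estimated value in this assay is 25000 nM, within a range from 8000 nM to 80000 nM.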

Compound 3, inhibition constant: 1100 nM
Beside the measured number, compound 3's estimate is 23-fold (1.36 log units) above it, and the stated range ends above it.
By their numbers in this assay, from the lowest: compound 3; then compound 2; then compound 1.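

In this assay, capping the carboxy group as methoxycarbonyl gives a 9.1-fold lower number from compound 2 to compound 3 (0.96 log units; beyond the scatter) and so makes a stronger inhibitor; at this position, then, the free carboxy group is not required for inhibition, and the methyl on that oxygen changes the number well beyond the scatter. With methoxycarbonyl held constant, the hydroxy on the saturated chain carbon also proves to matter, as adding it gives a 45-fold lower number from compound 1 to compound 3 (1.66 log units; beyond the scatter) in a large step that points to this chain carbon as a second sensitive place. Nothing given here explains either step.

On these data alone, whether ethoxycarbonyl or a primary amide in place of methoxycarbonyl would give a stronger or weaker inhibitor remains open. The same is true of a ketone carbonyl or a methoxy group in place of the hydroxy.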